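This account rests on a few compounds, and the source may have more. Where it says the series, first, only, none or still open, it means among the compounds named here.

Three ureas built on two closely related cores were examined in an assay on isolated protein for inhibition of serine/threonine-protein kinase 10 (Homo sapiens), read by thermal shift assay, tested at 10 uM; on this read-out higher numbers stand for stronger stabilisation of the target against heat and lower numbers for weaker stabilisation of the target. Compound 1, `CC(C)(C)c1cc(NC(=O)Nc2cc(C(F)(F)F)cc(C(F)(F)F)c2)n(C(C)(C)C)n1`, carries a tert-butyl group on an aromatic nitrogen and gives -0.7 degrees C. Compound 2, `CC(C)(C)c1cc(NC(=O)Nc2cc(C(F)(F)F)cc(C(F)(F)F)c2)n(-c2ccc(Br)cc2)n1`, differs from it in one place, (4-bromophenyl in place of tert-butyl on an aromatic nitrogen), and gives -0.3 degrees C. The step between the two is a number 0.40 degrees C higher from compound 1 to compound 2 (within the scatter). Compound 3, `CC(C)(C)c1cc(NC(=O)Nc2cc(F)cc(F)c2)n(C(C)(C)C)n1`, shares the tert-butyl group on the aromatic nitrogen with compound 1 but pairs it with a different aryl urea partner; the difference between the two cores is not broken down here. In this assay compound 3 gives -0.2 degrees C, a number that sits with those of compound 1 and compound 2 within the usual scatter, so no ranking among the three can be read from these values.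

Compound 4, `CC(C)(C)c1cc(NC(=O)Nc2cc(F)cc(F)c2)n(-c2ccc(Br)cc2)n1`, has not yet been measured. It stands to compound 3 as compound 2 stands to compound 1: 4-bromophenyl in place of tert-butyl on an aromatic nitrogen. This is the same change, made at the same place, and it is the second time it occurs among the compounds shown. Because the earlier instance produced a number 0.40 degrees C higher from compound 1 to compound 2 (within the scatter), the expected step here is a number 0.30 degrees C higher from compound 3 to compound 4 (within the scatter), resting on that single precedent alone and on the measured value of compound 3, -0.2 degrees C. On this basis compound 4 is estimated to give 0.1 degrees C, with a likely range from -0.9 degrees C to 1.1 degrees C.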

Compound 4, shift of the target's melting temperature: 0.2 degrees C
The estimate for compound 4 lay 0.10 degrees C below the measured number; the range from low to high includes it.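

In this assay, 4-bromophenyl in place of tert-butyl on an aromatic nitrogen gives a number 0.40 degrees C higher from compound 3 to compound 4 (within the scatter), and set beside the earlier instance, the two steps agree: the same change on two cores in this assay, a number 0.40 degrees C higher (within the scatter) from compound 1 to compound 2 and a number 0.40 degrees C higher (within the scatter) from compound 3 to compound 4, 0.000000000000000056 degrees C apart, within the scatter of two such steps. In this series, then, the change carries from the core of compound 1 to the core of compound 3 with no difference that can be told from the scatter. Among these compounds, this does not show that the change itself does anything to the stabilisation of the target, since each step lies within the scatter on its own, so the match is one between two small numbers, and it covers only two cores that differ in their aryl urea partner.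

The compounds shown leave open whether any group on this nitrogen can move the melting temperature beyond the scatter, for instance an unsubstituted phenyl, a longer alkyl chain, or a chain ending in an amine or a carboxylic acid. They also leave open whether the agreement between the two steps would hold on a core with another aryl urea partner, such as one carrying a nitrile or a methoxy group.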